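From Furan to Bromophenyl: Expecting a Modest Shift

This account rests on a few compounds, and the source may have more. Where it says the series, first, only, none or still open, it means among the compounds named here.

Three compounds share one core and differ only in the aromatic group attached to a carbon with a double bond to nitrogen. Compound 1 `CCOC(=O)c1c(N)sc(/N=C/c2ccncc2)c1C(=O)OCC` carries pyridin-4-yl, compound 2 `CCOC(=O)c1c(N)sc(/N=C/c2ccco2)c1C(=O)OCC` carries furan-2-yl and compound 3 `CCOC(=O)c1c(N)sc(/N=C/c2ccc([N+](=O)[O-])cc2)c1C(=O)OCC` carries 4-nitrophenyl. In a functional assay on Ishikawa cells (Homo sapiens) for inhibition, read by MTT assay, with a stated time of 48 h (a lower number here means a stronger inhibitor, a higher number a weaker inhibitor), compound 1 gives 119000 nM, compound 2 gives 69300 nM and compound 3 gives 141000 nM. Among the compounds with values here, compound 2 thus holds the lowest of the three numbers, yet one of its steps (a 1.7-fold lower number from compound 1 to compound 2 (0.23 log units; within the scatter)) lies within the scatter, so compound 1 and compound 2 cannot be ordered; only the step to compound 3 (a 2.0-fold higher number from compound 2 to compound 3 (0.31 log units; beyond the scatter)) counts as a modest rise.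

Compound 4 `CCOC(=O)c1c(N)sc(/N=C/c2ccc(Br)cc2)c1C(=O)OCC` has not been measured. It differs from compound 2 in one place: 4-bromophenyl in place of furan-2-yl on a carbon with a double bond to nitrogen. The closest guide is the step from compound 2 to compound 3, which also replaced furan-2-yl with a six-membered aromatic ring of carbon only and gave a modest increase. The step from compound 1 to compound 2 stayed within the scatter and adds little. A small rise in this assay is therefore expected, roughly a 1.6-fold higher number from compound 2 to compound 4 (0.20 log units; within the scatter). Compound 4 is estimated at 110000 nM, with a range from 55000 nM to 220000 nM.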

Compound 4, half-maximal inhibitory concentration: 46100 nM
Estimate against measurement, compound 4: 2.4-fold (0.38 log units) above; measured number outside the range, below it.
By their numbers in this assay, from the lowest: compounds 4, 2, 1 and 3 (each within the scatter of the next, the first and the last beyond it).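

In this assay, the step of a 1.5-fold lower number from compound 2 to compound 4 (0.18 log units; within the scatter) leaves compound 2 and compound 4 unseparated, so at this carbon with a double bond to nitrogen, 4-bromophenyl, with its six-membered aromatic ring of carbon only, cannot be told apart from the five-membered aromatic ring of furan-2-yl. Within the data shown here, the group on that six-membered ring can still shift the number on its own: bromo in place of nitro on an aromatic carbon gives a 3.1-fold lower number from compound 3 to compound 4 (0.49 log units; beyond the scatter) as a modest but real gap, and with a 2.6-fold lower number from compound 1 to compound 4 (0.41 log units; beyond the scatter) as a second gap beyond the scatter, compound 1 is for the first time separated from a compound other than by a step within the scatter. Nothing here explains why bromo and nitro differ in this way.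

On these data alone, whether chloro or methoxy in place of bromo on the 4-substituted phenyl ring would follow compound 4 or compound 3 remains open. So does the effect of a carboxylic acid in place of the ethyl esters on the shared core.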